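The Same Small Change on a Second Core

The source may hold more compounds than are shown below. What is called first, only, known or untested is meant among the compounds shown, and "the series" means these compounds.

Measured compounds:
compound 1 `CC(=O)Oc1ccc(/C=C/C(=O)OCCSc2nc(-c3ccc(S(C)(=O)=O)cc3)n(-c3ccccc3)n2)cc1OC(C)=O` gives 1210 nM
compound 2 `CC(=O)Oc1ccc(/C=C/C(=O)OCCSc2nc(-c3ccc(S(N)(=O)=O)cc3)n(-c3ccccc3)n2)cc1OC(C)=O` gives 1110 nM
compound 3 `CS(=O)(=O)c1ccc(-c2nc(SCCOC(=O)/C=C/c3ccc(O)c(O)c3)nn2-c2ccccc2)cc1` gives 850 nM

All three were tested in an assay on cells (strain Sprague-Dawley) for inhibition of Polyunsaturated fatty acid 5-lipoxygenase (Rattus norvegicus), with a stated time of 30 min; on this read-out higher numbers stand for weaker inhibition and lower numbers for stronger inhibition. Compound 1 and compound 2 share one core and differ in a single place: amino in place of methyl on a sulfonyl sulfur. That change produced a 1.1-fold lower number from compound 1 to compound 2 (0.04 log units; within the scatter), so the two values cannot be told apart with confidence.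

Compound 3 is built on a different core; the difference between the two cores is not broken down here. Its value and those of compound 1 and compound 2 all lie within the usual scatter of one another, so no ordering among the three can be claimed.

Compound 4 `NS(=O)(=O)c1ccc(-c2nc(SCCOC(=O)/C=C/c3ccc(O)c(O)c3)nn2-c2ccccc2)cc1` has not yet been measured. It is related to compound 3 exactly as compound 2 is related to compound 1: amino in place of methyl on a sulfonyl sulfur. The surroundings of the change are described in the same words in both pairs, so this is the same change seen a second time.

Among the measured compounds shown here, since the single earlier instance of this change gave a 1.1-fold lower number from compound 1 to compound 2 (0.04 log units; within the scatter), the step from compound 3 to compound 4 is expected to be small, about a 1.1-fold lower number from compound 3 to compound 4 (0.04 log units; within the scatter). On that basis compound 4 is estimated at 780 nM, with a plausible range from 400 nM to 1600 nM. This rests on one prior example only, so the expectation is loose.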

Compound 4, half-maximal inhibitory concentration: 800 nM
Compound 4: middle estimate off by 1.0-fold (0.01 log units), on the low side, and the stated range covers the measured number.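

In this assay, putting amino in place of methyl on the sulfonyl sulfur, which turns a 4-(methylsulfonyl)phenyl into a 4-sulfamoylphenyl, gave a 1.1-fold lower number from compound 3 to compound 4 (0.03 log units; within the scatter). Set beside the earlier instance of this change, the two steps agree: the same change on two cores in this assay, a 1.1-fold lower number (0.04 log units; within the scatter) from compound 1 to compound 2 and a 1.1-fold lower number (0.03 log units; within the scatter) from compound 3 to compound 4, 1.0-fold (0.01 log units) apart, within the scatter of two such steps

This shows that, across the core of compound 1 and the core of compound 3, the swap behaves alike in the sense that neither step can be told apart from the ordinary spread of repeated measurements, but it does not show that the swap has any real effect on this read-out, nor that it would stay this small on a third core, and two steps this small cannot show how a change with a clear effect would carry over.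

Still open, as far as these compounds go, is whether a different group on the sulfonyl sulfur, such as ethyl or dimethylamino, would give a step beyond the scatter on either core. Also open, from the compounds shown here alone, is whether the result would hold with an amide in place of the ester or with a longer chain between the ester and the sulfur attached to the core.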